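A few compounds are considered here, and "the series" means these few. Any claim that something is new, unique, unknown or untested is made for them only; others in the source may bear on it.

Of the compounds shown here, three share a fused two-ring core and have been measured in a functional assay on SNB-19 cells (Homo sapiens) for cytotoxicity, read by sulforhodamine B assay, with a stated time of 48 h; a higher number here means a weaker inhibitor of growth, a lower number a stronger inhibitor of growth. Compound 1 `Nc1nc(Cl)c2ncn(Cc3ccc(CCl)cc3)c2n1` gives 20000 nM. Compound 2 `ClCc1cccc(Cn2cnc3c(Cl)nc(Cl)nc32)c1` gives 4160 nM. Compound 3 `ClCc1ccc(Cn2cnc3c(Cl)nc(Cl)nc32)cc1` gives 7080 nM. Compound 2 and compound 3 are built from the same atoms joined differently; the difference between the two cores is not broken down here, and their two values lie within the scatter of each other, so nothing should be read into their order.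

Going by the values given here, the one change that is traced directly is the replacement of a chloro group by an amino group on the core. From compound 3 to compound 1 this is amino in place of chloro on an aromatic carbon, and it moved the value by a 2.8-fold higher number from compound 3 to compound 1 (0.45 log units; beyond the scatter), meaning weaker growth inhibition after the swap.

Compound 4 `Nc1nc(Cl)c2ncn(Cc3cccc(CCl)c3)c2n1` has not yet been measured in this assay. It stands to compound 2 as compound 1 stands to compound 3: the difference is amino in place of chloro on an aromatic carbon, the same change at the same kind of place. Because the step of a 2.8-fold higher number from compound 3 to compound 1 (0.45 log units; beyond the scatter) was modest and beyond the scatter, a step of about a 2.8-fold higher number from compound 2 to compound 4 (0.45 log units; beyond the scatter) is expected from compound 2 to compound 4. On that basis compound 4 is estimated at 11600 nM, with a likely range from 5000 nM to 28000 nM.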

Compound 4, concentration for total growth inhibition: 15100 nM
For compound 4 the middle estimate is 1.3-fold (0.11 log units) below the measured one; the measured number falls inside the stated range.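

The swap of chloro for amino on an aromatic carbon of the shared core can now be followed on two cores, and in this assay the second case gives a 3.6-fold higher number from compound 2 to compound 4 (0.56 log units; beyond the scatter), so growth inhibition again became weaker and by a similar amount as on the first core: the same change on two cores in this assay, a 2.8-fold higher number (0.45 log units; beyond the scatter) from compound 3 to compound 1 and a 3.6-fold higher number (0.56 log units; beyond the scatter) from compound 2 to compound 4, 1.3-fold (0.11 log units) apart, within the scatter of two such steps. Within this small set, then, the change carried over from one core to the other in both direction and size, and the step seen on one core would have been a fair guide to the step on the other. Going by these compounds alone, this rests on only two pairs of compounds in one cell line, so it does not show that the same step would appear on a core of a different kind, and it does not explain why the amino compounds are the weaker ones.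

The compounds shown leave open what other groups would do at the same aromatic carbon, for example a methoxy group, a methylamino group or a thiol, since only chloro and amino appear there. The second chloro group on the core is also the same in all four compounds, so replacing it with an amine or a methoxy group remains an untested question here.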